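Swapping a Urea for an Amide: What to Expect

A few compounds are considered here, and "the series" means these few. Any claim that something is new, unique, unknown or untested is made for them only; others in the source may bear on it.

Three measured compounds share one core. In a functional assay on HCT-116 cells (Homo sapiens) for inhibition, read by sulforhodamine B assay, with a stated time of 48 h (a lower number here means a stronger inhibitor, a higher number a weaker inhibitor), compound 1 `O=C(Nc1cccc(-n2cc(-c3ccncc3)c(-c3cc(O)cc(Cl)c3)n2)c1)Nc1ccc(Cl)c(C(F)(F)F)c1` gives 1960 nM, compound 2 `COc1cc(Cl)cc(-c2nn(-c3cccc(NC(=O)Nc4ccc(Cl)c(C(F)(F)F)c4)c3)cc2-c2ccncc2)c1` gives 630 nM, and compound 3 `COc1cc(Cl)cc(-c2nn(-c3cccc(NC(=O)Nc4cc(C(F)(F)F)cc(C(F)(F)F)c4)c3)cc2-c2ccncc2)c1` gives 330 nM. Compound 2 thus holds the second highest of the three numbers, close to compound 3 and clearly apart from compound 1. Compound 4 `COc1cc(Cl)cc(-c2nn(-c3cccc(NC(=O)c4cccc(C(F)(F)F)c4)c3)cc2-c2ccncc2)c1` has not been measured; it differs from compound 2 by 3-(trifluoromethyl)phenyl in place of (4-chloro-3-(trifluoromethyl)phenyl)amino on a carbonyl carbon. The only measured step, a 3.1-fold lower number from compound 1 to compound 2 (0.49 log units; beyond the scatter), concerns a different place, so nothing shown bears directly on this change, and the values of compound 2 and compound 3 speak only to the far end of that group. Compound 4 is expected to be a weaker inhibitor, with the step of a 4.0-fold higher number from compound 2 to compound 4 (0.60 log units; beyond the scatter) estimated, giving 2500 nM within 800 nM to 8000 nM.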

Compound 4, half-maximal inhibitory concentration: 3170 nM
Estimate against measurement, compound 4: 1.3-fold (0.10 log units) below; the measured number falls inside the stated range.
By their numbers in this assay, from the lowest: compounds 3 and 2 (each within the scatter of the next); then compounds 1 and 4 (each within the scatter of the next).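

In this assay, for the compounds shown here, the change from urea to amide weakens inhibition, with a 5.0-fold higher number from compound 2 to compound 4 (0.70 log units; beyond the scatter) at this carbonyl carbon, the first measured step at this place. The entering 3-(trifluoromethyl)phenyl lacks both the chlorine and the amino nitrogen with its hydrogen, so this one step cannot separate the two losses. Nothing shown explains the loss of activity.

Still open, on these data alone, is how a methylene group or an oxygen atom would behave in place of that amino nitrogen. Also open, as far as these compounds go, is whether a chlorine on the ring of compound 4 would change its activity.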